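Removing the terminal phenyl from the dichloroacetamide series

The compounds below may be only part of what the source reports. "The series", "measured", "known", "first", "only" and "open" are said of these compounds alone.

Values in a functional assay on A549 cells (Homo sapiens) for cytotoxicity, read by MTT assay, with a stated time of 68 h; a lower number here means a stronger inhibitor, a higher number a weaker inhibitor:
Compound 1 `O=C(Nc1cccc(-c2ccccc2C(F)(F)F)c1)C(Cl)Cl`: 7500 nM
Compound 2 `COc1ccc(-c2cccc(NC(=O)C(Cl)Cl)c2)cc1`: 8530 nM
Compound 3 `O=C(Nc1cccc(-c2ccc(-c3ccccc3)cc2)c1)C(Cl)Cl`: > 50000 nM (a limit, not a number)

Compound 3 sits at the limit of > 50000 nM in this assay, at which 1 of the 3 values shown sits. Compound 4 `Cc1ccc(-c2cccc(NC(=O)C(Cl)Cl)c2)cc1` differs from compound 3 as follows: methyl in place of phenyl on an aromatic carbon, with methyl in place of phenyl on an aromatic carbon, para to a large group. Among the measured compounds shown here, one measured step bears on this: an at least 5.8-fold higher number from compound 2 to compound 3 (0.76 log units; beyond the scatter), where phenyl replaced methoxy at that place. Losing the phenyl should therefore bring a lower number in this assay, close to compound 2 at 8530 nM. The expected change is an at least 5.5-fold lower number from compound 3 to compound 4 (0.74 log units; beyond the scatter). Compound 4 is estimated at 9000 nM, with an expected range of 4000 nM to 25000 nM.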

Compound 4, half-maximal inhibitory concentration: 8300 nM
Compound 4: the middle estimate sits 1.1-fold (0.04 log units) above what was measured; measured number inside the range.
By their numbers in this assay, from the lowest: compounds 1, 4 and 2 (each within the scatter of the next). At a limit, above all of these: compound 3.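

In this assay, methyl in place of the terminal phenyl gives an at least 6.0-fold lower number from compound 3 to compound 4 (0.77 log units; beyond the scatter), so the second route away from compound 3 lands at the same level as the first. At this place, methyl and methoxy cannot be told apart, with a 1.0-fold lower number from compound 2 to compound 4 (0.01 log units; within the scatter). Compound 3 stands at a limit, not a number, so the full size of the phenyl step stays unknown: the limit of > 50000 nM in this assay, at which 1 of the 4 values shown sits.

On these data alone, whether an amine, a carboxylic acid or a longer chain at this place stays level with compound 4 or moves towards compound 3 remains open.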